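Inversion at the ring stereocentre of compound 1

The source may report more compounds than this note shows. Statements on the series, on what has been measured and on what is new or still open speak of the compounds shown alone.

Compound 1 `N[C@@]1(C(=O)O)CN(C[C@@H]2COCCN2)C[C@@H]1CCCB(O)O` stands at 10 nM in an assay for inhibition of arginase-1 (Homo sapiens), read by colorimetric assay, with a stated time of 60 min, in the presence of a further agent that is not named here (a lower number here means a stronger inhibitor, a higher number a weaker inhibitor), the lowest of the three numbers, though compound 3 sits within the scatter of it. Compound 3 `C[C@@H](N)CN1C[C@H](CCCB(O)O)[C@](N)(C(=O)O)C1` gives 16 nM in this assay, a step of a 1.6-fold higher number from compound 1 to compound 3 (0.20 log units; within the scatter). Compound 2 `Cc1[nH]ncc1CN1C[C@H](CCCB(O)O)[C@](N)(C(=O)O)C1` gives 400 nM, a large step: a 40-fold higher number from compound 1 to compound 2 (1.60 log units; beyond the scatter). Compound 4 `N[C@@]1(C(=O)O)CN(C[C@H]2COCCN2)C[C@@H]1CCCB(O)O` differs from compound 1 only in configuration: the two compounds have the same atoms and bonds and differ only in configuration as drawn: 1 of 3 stereo elements differ; a stereocentre at a saturated ring carbon is drawn R in compound 1 and S in compound 4. Among the compounds with values here, no measured step inverts a stereocentre; the steps to compound 2 and compound 3 each replace the whole group on the saturated chain carbon bound to the amine nitrogen in the ring, so neither bears directly on this change. Given that compound 3 gives 16 nM with the ring replaced by a group of 3 heavy atoms, for compound 4 a step within the scatter or slightly weaker is expected, a 2.0-fold higher number from compound 1 to compound 4 (0.30 log units; within the scatter). Compound 4 is estimated at 20 nM in this assay, range 6 nM to 80 nM.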

Compound 4, half-maximal inhibitory concentration: 19 nM
Compound 4: middle estimate off by 1.1-fold (0.02 log units), on the high side; the range from low to high includes it.
By their numbers in this assay, from the lowest: compounds 1, 3 and 4 (each within the scatter of the next); then compound 2.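

In this assay, inverting the stereocentre at the saturated ring carbon gives a 1.9-fold higher number from compound 1 to compound 4 (0.28 log units; within the scatter), so at this position neither drawn configuration separates from the other, and the comparison isolates that single stereo element: the fact that compounds 1 and 4 differ only in the configuration as drawn

With the S configuration, the ring group also stays within the scatter of the open-chain group of compound 3, at a 1.2-fold higher number from compound 3 to compound 4 (0.07 log units; within the scatter). The large gap to the pyrazole group remains, at a 21-fold lower number from compound 2 to compound 4 (1.32 log units; beyond the scatter).

As far as these compounds go, whether a piperidine ring on the same chain carbon would show the same insensitivity to inversion stays open. So does the effect of inverting the stereocentre in the side chain of compound 3.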